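A few compounds are considered here, and "the series" means these few. Any claim that something is new, unique, unknown or untested is made for them only; others in the source may bear on it.

Series notes, cytotoxicity in HepG2-derived cells.

Compound 1 `COc1ccc2c(=O)c(/C=C/C(=O)NCc3cccc(F)c3)coc2c1` is measured in an ADME assay on HepG2 2.2.15 cells (Homo sapiens) for cytotoxicity, read by MTT assay, with stated times of 48 h and 9 days (on this read-out lower numbers stand for higher toxicity in this test and higher numbers for lower toxicity in this test), where compound 1 gives 475000 nM. Among the three numbers in hand this is the highest, though neither neighbour is separated from it beyond the scatter. Compound 2 `O=C(/C=C/c1coc2cc(O)ccc2c1=O)NCc1ccccc1` gives 436000 nM in this assay, and compound 3 `COc1ccc2c(=O)c(/C=C/C(=O)NCc3ccc(C)cc3)coc2c1` gives 257000 nM. Among the measured compounds shown here, the only single-point step in the set is a 1.8-fold lower number from compound 1 to compound 3 (0.27 log units; within the scatter), which is within the scatter; compound 2 shares no single-point step with compound 1, and its value sits close to that of compound 1.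

Compound 4 `COc1cccc(NC(=O)/C=C/c2coc3cc(OC)ccc3c2=O)c1` has not yet been measured. It differs from compound 1 by 3-methoxyphenyl in place of 3-fluorobenzyl on an amide-type nitrogen. For the measured compounds named here, the one step that bears on this change, the replacement of the group on the amide nitrogen side from compound 1 to compound 3, gave no movement beyond the scatter; the present change also alters that side of the molecule. Going by the values given here, no measured step speaks for a shift in either direction here. Compound 4 is therefore expected to stay near the value of compound 1, with an estimated step of a 1.1-fold lower number from compound 1 to compound 4 (0.05 log units; within the scatter). Compound 4 is estimated at 420000 nM, within a range from 200000 nM to 900000 nM.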

Compound 4, half-maximal cytotoxic concentration: 1130000 nM
For compound 4 the middle estimate is 2.7-fold (0.43 log units) below the measured one; measured number above the stated range.
By their numbers in this assay, from the lowest: compounds 3, 2 and 1 (each within the scatter of the next); then compound 4.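

In this assay the group on the amide-type nitrogen can move the number beyond the scatter, which the earlier step between two benzyl groups did not show. 3-Methoxyphenyl in place of 3-fluorobenzyl gives a 2.4-fold higher number from compound 1 to compound 4 (0.38 log units; beyond the scatter) and, in place of 4-methylbenzyl, gives a 4.4-fold higher number from compound 3 to compound 4 (0.64 log units; beyond the scatter) as well; both steps are modest and both point towards lower toxicity in this test. Nothing at hand bears on why this change shifts the number.

The change swaps benzyl for phenyl and brings in a methoxy group in a single step, so the compounds shown do not tell which of the two goes with the higher number; a 3-methoxybenzyl or a 3-fluorophenyl group on the same nitrogen would separate them. From the compounds shown here alone, it also remains open whether the number stays high with other groups on the phenyl ring, such as an amine or a carboxylic acid, and whether a longer chain on the amide-type nitrogen behaves like the benzyl or the phenyl compounds.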